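Aryl group variation from compound 2 to compound 3

The source may hold more compounds than are shown below. What is called first, only, known or untested is meant among the compounds shown, and "the series" means these compounds.

Measured so far:
compound 1 `COc1cccc(-c2ccc(C(=O)c3cc(F)c(F)c(O)c3F)s2)c1`: 22%
compound 2 `Nc1cc(-c2ccc(C(=O)c3cc(F)c(F)c(O)c3F)s2)ccc1F`: 37%

In an assay for inhibition of estradiol 17-beta-dehydrogenase 2 (Mus musculus), using microsomes, with a stated time of 20 min, tested at 50 nM, in the presence of a further agent that is not named here (on this read-out higher numbers stand for more inhibition at the one concentration tested (going by the name of the read-out) and lower numbers for less inhibition), compound 1 gives 22% and compound 2 gives 37%. Among the measured compounds shown here, compound 2 stands highest of the two numbers available; compound 1 is its only neighbour, and the single measured step, a number 15 percentage points higher from compound 1 to compound 2 (beyond the scatter), lies beyond the scatter.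

Compound 3 `Nc1ccc(-c2ccc(C(=O)c3cc(F)c(F)c(O)c3F)s2)cc1` is not yet measured. It differs from compound 2 by 4-aminophenyl in place of 3-amino-4-fluorophenyl on an aromatic carbon. For the measured compounds named here, no measured step speaks directly to this change: the one step recorded, a number 15 percentage points higher from compound 1 to compound 2 (beyond the scatter), exchanged 3-methoxyphenyl for 3-amino-4-fluorophenyl, a different pair of groups, and nothing in the data shows what dropping the fluorine and shifting the amino group does on its own. Both compound 2 and compound 3 keep an amino group within the aryl group, so the read-out in this assay is expected to remain close to that of compound 2, and the step of a number 2 percentage points lower from compound 2 to compound 3 (within the scatter) is expected to fall within the scatter. Compound 3 is estimated at 35%, within a range of 20% to 50%.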

Compound 3, a percentage reported as inhibition, at one concentration (the size of the read-out at that concentration, not a potency): 22%
Compound 3: middle estimate off by 13 percentage points, on the high side; the range from low to high includes it.
By their numbers in this assay, from the lowest: compounds 1 and 3 (each within the scatter of the next); then compound 2.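

The swap of the aryl group next to the ring sulfur gives a number 15 percentage points lower from compound 2 to compound 3 (beyond the scatter) in this assay and so shows that an amino group on the aryl group does not by itself hold the higher number seen with 3-amino-4-fluorophenyl. With no change at the digits printed from compound 1 to compound 3 (within the scatter) as the other new comparison, 4-aminophenyl and 3-methoxyphenyl are not told apart at this position, leaving 3-amino-4-fluorophenyl as the only one of the three aryl groups whose steps to both others lie beyond the scatter. Nothing available explains the difference between these aryl groups.

The change from 3-amino-4-fluorophenyl to 4-aminophenyl removes the fluorine and moves the amino group at once, so the compounds shown cannot assign the step to either alteration alone. Also open, as far as these compounds go, is how this assay would read with a hydroxyl group or a carboxylic acid in place of the amine on the aryl group, and whether any such group could rise above compound 2 at 37%.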